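Benzoyl added to compound 1: an estimate without a baseline

This account rests on a few compounds, and the source may have more. Where it says the series, first, only, none or still open, it means among the compounds named here.

- compound 1 `NCCCNc1c(C(=O)NCc2ccc(F)cc2)nc(Br)c2cccnc12` with "not determined" (no result reported) as its entry
- compound 2 `Nc1ccc(Nc2c(C(=O)NCc3ccc(F)cc3)nc(Br)c3cccnc23)cc1` with 7000 nM as its value
- compound 3 `N[C@H]1CC[C@H](Nc2c(C(=O)NCc3ccc(F)cc3)nc(Br)c3cccnc23)CC1` with 5000 nM as its value

In a functional assay on LNCaP cells (Homo sapiens) for cytotoxicity, read by MTT assay, with a stated time of 72 h (on this read-out lower numbers stand for stronger inhibition and higher numbers for weaker inhibition), compound 1 stands at "not determined" (no result reported) and so offers no starting number. The change to compound 4 `O=C(NCCCNc1c(C(=O)NCc2ccc(F)cc2)nc(Br)c2cccnc12)c1ccccc1` is benzoyl in place of hydrogen on an amine nitrogen and puts benzoyl in place of hydrogen on an amine nitrogen. Within the data shown here, the one measured step is a 1.4-fold lower number from compound 2 to compound 3 (0.15 log units; within the scatter) and concerns a different group, so it gives no expected size or direction for this change. The expectation rests only on the level set by compound 2 at 7000 nM and compound 3 at 5000 nM in the same series. Compound 4 is estimated at 5000 nM with an expected range from 1500 nM to 20000 nM for its measurement.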

Compound 4, half-maximal inhibitory concentration: > 10000 nM
Compound 4: no number, only a limit (the forecaster's own chance of this, stated with the estimate: 15%); at least 2.0-fold (0.30 log units) between middle value and limit.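

Among these compounds, with no number for compound 1, no step to compound 4 can be read. Compound 4 stands at > 10000 nM, which is a limit and not a number. As far as these compounds go, what benzoyl in place of hydrogen on the amine nitrogen changes in this read-out stays open.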